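Tetrazolylacetamide series: aryl change from compound 3 to compound 4

The compounds below may be only part of what the source reports. "The series", "measured", "known", "first", "only" and "open" are said of these compounds alone.

For the measured compounds named here, compound 3 `Cc1cc(NC(=O)Cn2nnc(-c3ccc(F)cc3)n2)n(C2CCCCC2)n1` stands lowest of the two numbers so far in an assay on HEK293 cells for activation of Kir3.1/Kir3.2 (Homo sapiens), read by thallium flux (on this read-out lower numbers stand for an effect already at smaller amounts and higher numbers for an effect only at larger amounts of compound), giving 180 nM. Compound 1 `O=C(Cn1nnc(-c2ccccc2)n1)Nc1cc(C2CC2)nn1C1CCCCC1` is the nearest entry, and in this assay compound 1 gives 271 nM, a gap that lies within the scatter, so no order is read between compound 3 and compound 1. Compound 2 `Cc1nc(NC(=O)Cn2nnc(-c3ccccc3)n2)n(-c2ccccc2)n1` carries a different core and in this assay compound 2 is reported as "not active" (no number reported), without a number.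

Compound 4 `Cc1cc(NC(=O)Cn2nnc(-c3cccc(C(F)(F)F)c3)n2)n(C2CCCCC2)n1` is yet to be measured. Its change from compound 3 is 3-(trifluoromethyl)phenyl in place of 4-fluorophenyl on an aromatic carbon: 3-(trifluoromethyl)phenyl in place of 4-fluorophenyl, on an aromatic carbon of the five-membered aromatic ring with four nitrogen, two ring bonds from the ring nitrogen that bears the large group. Going by the values given here, no measured pair in this set covers such a change, so the size of the step cannot be read from data here; a step of modest size, likely toward higher numbers in this assay or none beyond the scatter, is expected, a 1.9-fold higher number from compound 3 to compound 4 (0.29 log units; within the scatter). Compound 4 is estimated at 350 nM in this assay, with a range from 120 nM to 1000 nM.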

Compound 4, half-maximal effective concentration: 183 nM
Compound 4: the middle estimate sits 1.9-fold (0.28 log units) above what was measured; the range from low to high includes it.
By their numbers in this assay, from the lowest: compounds 3, 4 and 1 (each within the scatter of the next).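

On the aromatic carbon of the five-membered aromatic ring with 4 nitrogen, 3-(trifluoromethyl)phenyl in place of 4-fluorophenyl gives a 1.0-fold higher number from compound 3 to compound 4 (0.01 log units; within the scatter) in this assay. For the compounds shown here, this is the first step between measured compounds that differ in one place, and it shows that this position accepts an entering group of 10 heavy atoms in place of one of 7 with no step beyond the scatter. No measurement at hand bears on the reason for this result.

The step alters both the substituent and its place on the phenyl ring, and the compounds shown do not separate the two, as 4-(trifluoromethyl)phenyl at this position would. As far as these compounds go, whether a carboxylic acid or a primary amine on that phenyl ring would leave the number within the same range also remains open.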